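Trifluoromethyl in place of methoxy in an antiproliferative series

A few compounds are considered here, and "the series" means these few. Any claim that something is new, unique, unknown or untested is made for them only; others in the source may bear on it.

In a functional assay on MDA-MB-231 cells (Homo sapiens) for antiproliferative activity, with a stated time of 4 days (a lower number here means a stronger inhibitor, a higher number a weaker inhibitor), two compounds have been measured so far. Compound 1 (`CCCCc1ccc2[nH]c(-c3ccc(C(F)(F)F)cc3)c(/C=N/NC(=O)c3cccnc3)c2c1`) gives 97 nM as its half-maximal inhibitory concentration, and compound 2 (`CCCCc1ccc2[nH]c(-c3ccc(OC)cc3)c(/C=N/NC(=O)c3ccccn3)c2c1`) gives 34 nM as its own. Compound 2 thus holds the lower of the two numbers, and its gap to compound 1 lies beyond the scatter of repeated measurements. Within the data shown here, these two compounds differ in more than one place, so the data contain no measured step for a single change.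

Compound 3 (`CCCCc1ccc2[nH]c(-c3ccc(C(F)(F)F)cc3)c(/C=N/NC(=O)c3ccccn3)c2c1`) departs from compound 2 in one place, with trifluoromethyl in place of methoxy on an aromatic carbon, para to a large group (trifluoromethyl in place of methoxy on an aromatic carbon). The only hint at the size of this change comes from compound 1, which also carries trifluoromethyl and gives the higher number (97 nM), although it differs from compound 2 elsewhere as well. The expected step is a modest one toward a higher number (a 1.8-fold higher number from compound 2 to compound 3 (0.25 log units; within the scatter)) and may not clear the scatter. For compound 3 the estimated value is 60 nM (expected range 22 nM to 160 nM).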

Compound 3, half-maximal inhibitory concentration: 260 nM
Compound 3: the middle estimate sits 4.3-fold (0.64 log units) below what was measured, outside the stated range (above it).
By their numbers in this assay, from the lowest: compound 2; then compound 1; then compound 3.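

In this assay, among these compounds, the step of a 7.6-fold higher number from compound 2 to compound 3 (0.88 log units; beyond the scatter) is the first measured change at this place, on an aromatic carbon para to a large group, and it shows that the 4-methoxyphenyl to 4-(trifluoromethyl)phenyl exchange weakens the compound by a clear margin when all else is held fixed. With trifluoromethyl held in place, pyridin-2-yl in place of pyridin-3-yl on a carbonyl carbon gives a 2.7-fold higher number from compound 1 to compound 3 (0.43 log units; beyond the scatter), so the pyridine attached to the carbonyl also affects the read-out, and this step too lies beyond the scatter. No evidence at hand bears on the reason for either step.

The compounds shown leave open whether the trifluoromethyl step keeps its size with pyridin-3-yl on the carbonyl carbon, and whether the step between the two pyridines runs the same way with methoxy on the aromatic ring. On these data alone, it is also open whether an ethoxy group or a chlorine atom at this place would read closer to compound 2 or to compound 3.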